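Cyclopropyl for methyl on the sulfonyl: tolerability expected unchanged

The source may hold more compounds than are shown below. What is called first, only, known or untested is meant among the compounds shown, and "the series" means these compounds.

Compound 1, `CS(=O)(=O)CCn1c(Cn2cc(S(C)(=O)=O)c3ccccc32)nc2cc(Cl)ccc21`: in an ADME assay on HEp-2 cells (Homo sapiens) for cytotoxicity, with a stated time of 4 days (a higher number here means that more compound is tolerated, a lower number that less compound is tolerated), compound 1 gives > 100000 nM, which is a limit of the assay rather than a number.
Compound 2, `CS(=O)(=O)CCCn1c(Cn2cc(S(C)(=O)=O)c3ccccc32)nc2cc(Cl)ccc21`: in this assay compound 2 gives > 100000 nM, likewise a limit.
Compound 3, `CS(=O)(=O)CCn1c(Cn2c(S(C)(=O)=O)cc3ccccc32)nc2ccccc21`: in this assay compound 3 gives > 100000 nM, again a limit.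

Within the data shown here, compound 2 thus stands at the limit of > 100000 nM in this assay, at which 3 of the 3 values shown sit, and no measured compound falls below that limit. Among the measured compounds shown here, the only one-place step among the measured compounds is a step that the two limits leave unreadable from compound 1 to compound 2, which the two limits leave without a readable size. Compound 4, `CS(=O)(=O)CCCn1c(Cn2cc(S(=O)(=O)C3CC3)c3ccccc32)nc2cc(Cl)ccc21`, differs from compound 2 by cyclopropyl in place of methyl on a sulfonyl sulfur. For the measured compounds named here, no measured step bears directly on this change, and the one measured step has no size, so there is no ground for expecting a move in this assay beyond the scatter in either direction. The step that the limit leaves unreadable from compound 2 to compound 4 is therefore expected to be essentially none. Compound 4 is expected to sit at 150000 nM, with a range from 50000 nM to 500000 nM, and most likely to be reported again only as a limit.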

Compound 4, half-maximal cytotoxic concentration: > 100000 nM
Compound 4 was reported as a limit; the forecaster's own chance of this, stated with the estimate: 85%; the middle value is on the limit's open side.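

Compound 2 and compound 4 are both reported only as limits, so no size can be read for the change from methyl to cyclopropyl on the sulfonyl sulfur. The compounds shown leave open at what concentration any of them would harm the cells in this assay, as every value stands at one limit: the limit of > 100000 nM in this assay, at which 4 of the 4 values shown sit.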